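The compounds below may be only part of what the source reports. "The series", "measured", "known", "first", "only" and "open" are said of these compounds alone.

Compound 1 `COc1cc(/C=C2\CN(C)C/C(=C\c3ccccc3F)C2=O)cc(OC)c1OC`: 3220 nM
Compound 2 `CN1C/C(=C\c2cccc([N+](=O)[O-])c2)C(=O)/C(=C/c2ccccc2F)C1`: 2340 nM
Compound 3 `COc1cc(/C=C2\CN(C)C/C(=C\c3ccc(Br)cc3)C2=O)cc(OC)c1`: 5900 nM

All three were tested in a functional assay on HeLa cells (Homo sapiens) for cytotoxicity, read by MTT assay, with a stated time of 24 h; on this read-out higher numbers stand for weaker inhibition and lower numbers for stronger inhibition. Compound 3 at 5900 nM lies within the usual scatter of compound 1, but its number is higher than that of compound 2, a gap beyond the scatter.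

Compound 4 `COc1cc(/C=C2\CN(C)C/C(=C\c3cccc([N+](=O)[O-])c3)C2=O)cc(OC)c1` has 3-nitrophenyl in place of 4-bromophenyl on a double-bonded chain carbon bound to a double-bonded ring carbon. Within the data shown here, no measured pair isolates this change, so any forecast is loose. Compound 2 also carries 3-nitrophenyl and gives 2340 nM, so a small drop in the number is expected in this assay, possibly none beyond the scatter. The estimated change is a 1.6-fold lower number from compound 3 to compound 4 (0.20 log units; within the scatter). For compound 4 the expected value is 3700 nM, with an estimated range of 1600 nM to 8500 nM.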

Compound 4, half-maximal inhibitory concentration: 2560 nM
Beside the measured number, compound 4's estimate is 1.4-fold (0.16 log units) above it, and the stated range covers the measured number.
By their numbers in this assay, from the lowest: compounds 2, 4, 1 and 3 (each within the scatter of the next, the first and the last beyond it).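

In this assay, among these compounds, putting 3-nitrophenyl in place of 4-bromophenyl on a double-bonded chain carbon bound to a double-bonded ring carbon gives a 2.3-fold lower number from compound 3 to compound 4 (0.36 log units; beyond the scatter), the first comparison here that isolates a single change. The number at this position therefore responds to the group it carries, though the step is modest. Nothing measured here explains the shift.

The change replaces both the substituent and its numbered place on the phenyl ring, and the compounds shown do not separate the two. As far as these compounds go, how an aminophenyl group would behave at this position also remains open.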